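The compounds below may be only part of what the source reports. "The series", "measured", "known", "first", "only" and "open" are said of these compounds alone.

Measured so far in an assay on FRT cells for positive allosteric modulation of Cystic fibrosis transmembrane conductance regulator variant N1303K (Homo sapiens), in the presence of a further agent that is not named here; a lower number here means that less compound is needed, a higher number that more compound is needed for the effect:
compound 1 `COc1ccc2[nH]c3c(c2c1)CCNC31CCN(Cc2c(F)ccc(Cl)c2F)CC1` gives 1500 nM
compound 2 `COc1ccc2[nH]c3c(c2c1)CCNC31CCN(Cc2ccc(Br)cc2F)CC1` gives 1600 nM

Compound 2 has the higher of the two numbers, but the two values lie within the scatter of each other. Compound 3 `COc1ccc2[nH]c3c(c2c1)CCNC31CCN(Cc2ccccn2)CC1` differs from compound 2 by pyridin-2-yl in place of 4-bromo-2-fluorophenyl on a saturated chain carbon bound to an amine nitrogen in a ring. For the measured compounds named here, the only measured step, a 1.1-fold higher number from compound 1 to compound 2 (0.03 log units; within the scatter), exchanges one halogenated ring for another and stays within the scatter; no step in this assay covers the removal of all ring halogens together with the entry of a ring nitrogen. The change is therefore expected to move the number somewhat upward, with wide uncertainty, in this assay, giving a 1.9-fold higher number from compound 2 to compound 3 (0.27 log units; within the scatter). Compound 3 is estimated at 3000 nM, in the range 1000 nM to 10000 nM.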

Compound 3, half-maximal effective concentration: 11500 nM
The estimate for compound 3 lay 3.8-fold (0.58 log units) below the measured number; the whole stated range lies below it.
By their numbers in this assay, from the lowest: compounds 1 and 2 (each within the scatter of the next); then compound 3.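

In this assay, the aryl group on a saturated chain carbon bound to an amine nitrogen in a ring now makes a difference beyond the scatter: pyridin-2-yl gives a 7.2-fold higher number from compound 2 to compound 3 (0.86 log units; beyond the scatter) and a 7.7-fold higher number from compound 1 to compound 3 (0.88 log units; beyond the scatter). The two halogenated rings alone gave no such separation. Nothing measured on hand accounts for the rise. Each step removes the halogens and brings in the ring nitrogen together, and the compounds shown do not separate these two changes. Plain unsubstituted phenyl at this place would bear on that question.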